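Swapping one tertiary amine for another on a protected lipid scaffold

This account rests on a few compounds, and the source may have more. Where it says the series, first, only, none or still open, it means among the compounds named here.

Measured compounds in a functional assay on A549 cells (Homo sapiens) for antiproliferative activity, read by sulforhodamine B assay, with a stated time of 48 h, tested at 10 uM; a lower number here means less inhibition, a higher number more inhibition at the concentration tested (going by the name of the read-out):
- compound 1, `CCCCCCCCCCCCCC[C@H](OCOC)[C@H](CO[Si](c1ccccc1)(c1ccccc1)C(C)(C)C)NC(=O)OC(C)(C)C`: 15.1%
- compound 2, `CCCCCCCCCCCCCC[C@H](OCOC)[C@H](CO)NC(=O)OC(C)(C)C`: 25.9%
- compound 3, `CCCCCCCCCCCCCC[C@H](OCOC)[C@H](CN(C(C)C)C(C)C)NC(=O)OC(C)(C)C`: 22.6%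

Compound 3 sits among three values that all lie within the usual scatter of one another: compound 2 differs from it by a step that is within the scatter, and compound 1 is only slightly further off, also within the scatter. Compound 4, `CCCCCCCCCCCCCC[C@H](OCOC)[C@H](CN1CCCCC1)NC(=O)OC(C)(C)C`, differs from compound 3 by piperidin-1-yl in place of diisopropylamino on a saturated chain carbon, two bonds along the chain from an amide-type nitrogen. Going by the values given here, no measured pair shows this exact swap of one tertiary amine for another. The closest reference is a number 3.3 percentage points lower from compound 2 to compound 3 (within the scatter), a small step within the scatter. With only that to go on, no change beyond the scatter is expected for compound 4 in this assay; the step of a number 0.4 percentage points higher from compound 3 to compound 4 (within the scatter) is an estimate of essentially no movement. Compound 4 is therefore expected to give about 23%, somewhere between 10% and 36%.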

Compound 4, a percentage reported as inhibition, at one concentration (the size of the read-out at that concentration, not a potency): 19%
Compound 4: the middle estimate sits 4 percentage points above what was measured, within the range that was stated.
By their numbers in this assay, from the lowest: compounds 1, 4, 3 and 2 (each within the scatter of the next, the first and the last beyond it).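

In this assay, piperidin-1-yl in place of diisopropylamino gives a number 3.6 percentage points lower from compound 3 to compound 4 (within the scatter), and piperidin-1-yl in place of hydroxy gives a number 6.9 percentage points lower from compound 2 to compound 4 (within the scatter). At this saturated chain carbon, then, a ring amine cannot be told apart from either the open-chain amine or the hydroxy group. No supporting measurement offers an explanation for these numbers.

On these data alone, whether a morpholine ring or a free primary amine on this carbon would give a step beyond the scatter remains open. So does the effect of a shorter chain on the shared core.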